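The compounds below may be only part of what the source reports. "The series", "measured", "known", "first", "only" and "open" are said of these compounds alone.

In a functional assay on HT-29 cells (Homo sapiens) for cytotoxicity, read by MTT assay, with a stated time of 3 days (a lower number here means a stronger inhibitor, a higher number a weaker inhibitor), compound 1 `COc1ccc(-c2ccccc2)cc1` gives 45 ug/mL and compound 2 `Nc1ccccc1-c1ccc(O)cc1` gives 51 ug/mL while compound 3 `COc1ccc(-c2cccc(O)c2)cc1` gives 72 ug/mL in the same read-out. None of the three values is separated from another beyond the scatter, so compound 1 stands level with compound 2 and compound 3.

The change to compound 4 `COc1ccc(-c2ccccc2)c(OC)c1` is methoxy in place of hydrogen on an aromatic carbon on the core of compound 1, that is, methoxy in place of hydrogen on an aromatic carbon. Among the measured compounds shown here, the one measured step that bears on it is a 1.6-fold higher number from compound 1 to compound 3 (0.20 log units; within the scatter) for hydroxy in place of hydrogen on an aromatic carbon. For the measured compounds named here, that step involves a different group, and no measured step adds methoxy, so it offers only loose guidance.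

No step beyond the scatter is expected in this assay for this change. The estimated step is a 1.1-fold higher number from compound 1 to compound 4 (0.05 log units; within the scatter) and these data do not settle its direction. The estimated value for compound 4 is 50 ug/mL with 25 ug/mL to 100 ug/mL as the expected range.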

Compound 4, half-maximal inhibitory concentration: 55.2 ug/mL
Beside the measured number, compound 4's estimate is 1.1-fold (0.04 log units) below it, and the stated range covers the measured number.
By their numbers in this assay, from the lowest: compounds 1, 2, 4 and 3 (each within the scatter of the next).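

In this assay, methoxy in place of hydrogen on an aromatic carbon, ortho to a group of 6 heavy atoms and meta to a methoxy group, gives a 1.2-fold higher number from compound 1 to compound 4 (0.09 log units; within the scatter). Among the compounds shown here, this is the first step that adds methoxy itself, and like the hydroxy step, a 1.6-fold higher number from compound 1 to compound 3 (0.20 log units; within the scatter), it leaves the number within the scatter of compound 1, so this position takes the added group with no measurable shift in this read-out. Nothing available gives a reason for this result.

As far as these compounds go, whether another group at this position, such as an amine, a carboxylic acid or a longer chain, would give a step beyond the scatter remains open. Also open, from the compounds shown here alone, is whether methoxy at other places on the core of compound 1 would stay within the scatter as well.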